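A Methyl Added to a Weak Inhibitor

A few compounds are considered here, and "the series" means these few. Any claim that something is new, unique, unknown or untested is made for them only; others in the source may bear on it.

Compound 1, `CCN(CC)Cc1cc(C)cc(Nc2nc3ccccc3[nH]2)c1O`, gives in an ADME assay on CHO cells (Cricetulus griseus) for inhibition, read by MTT assay (a lower number here means a stronger inhibitor, a higher number a weaker inhibitor), only the limit > 50000 nM.
Compound 2, `Cc1cc(CNC(C)(C)C)c(O)c(Nc2nc3ccccc3n2Cc2ccc(C(F)(F)F)cc2)c1`, gives in this assay a value of 30000 nM.
Compound 3, `CCN(CC)Cc1cccc(Nc2nc3ccccc3n2Cc2ccc(C(F)(F)F)cc2)c1O`, gives in this assay only the limit > 50000 nM.

Compound 3 thus stands at the edge of what this assay can report: its result is a limit, not a number, and it shares that position with compound 1, as the limit of > 50000 nM in this assay, at which 2 of the 3 values shown sit, shows. Compound 2 is the only one of the three with a measured number, and that number is itself high, so all three compounds are weak inhibitors in this assay.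

Compound 4, `CCN(CC)Cc1cc(C)cc(Nc2nc3ccccc3n2Cc2ccc(C(F)(F)F)cc2)c1O`, has not yet been measured. It differs from compound 3 by methyl in place of hydrogen on an aromatic carbon. Going by the values given here, no pair of measured compounds differs in exactly this way, so the size of this step cannot be read from the data. Compound 1 carries the same methyl and the same (diethylamino)methyl group and also sits at the limit, and compound 2 carries a methyl and gives a number close to that limit. The expectation is that the step of a number no higher from compound 3 to compound 4 (the limit leaves the size open) stays within the usual scatter, with no direction beyond it. Compound 4 is expected to give about 50000 nM, between 20000 nM and 120000 nM, most likely again reported only as a limit.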

Compound 4, half-maximal inhibitory concentration: 29300 nM
Estimate against measurement, compound 4: 1.7-fold (0.23 log units) above; measured number inside the range.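

Methyl in place of hydrogen on the aromatic carbon para to a hydroxy group gives an at least 1.7-fold lower number from compound 3 to compound 4 (0.23 log units; that floor lies within the scatter), and 4-(trifluoromethyl)benzyl in place of hydrogen on the aromatic nitrogen gives an at least 1.7-fold lower number from compound 1 to compound 4 (0.23 log units; that floor lies within the scatter). Each of these steps is only a floor, and neither can be sized or placed beyond the scatter, because one end of each step is a limit rather than a number: the limit of > 50000 nM in this assay, at which 2 of the 4 values shown sit. Diethylamino in place of (tert-butyl)amino on the saturated chain carbon bound to an aromatic carbon gives a 1.0-fold lower number from compound 2 to compound 4 (0.01 log units; within the scatter), so with the methyl present these two amines cannot be told apart in this assay.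

From the compounds shown here alone, the true size of the methyl step stays open, and so does the question of whether the methyl and the 4-(trifluoromethyl)benzyl group each matter alone or only together. Also unknown is what a chlorine atom or a methoxy group would give at the place of the methyl, or a pyrrolidine or a primary amine in place of the diethylamino group, in this assay.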